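Butyl Ester to Isopropyl Thioester on a Dienoate Chain

The source may report more compounds than this note shows. Statements on the series, on what has been measured and on what is new or still open speak of the compounds shown alone.

Of the compounds shown here, two have been measured in a physicochemical assay for lipophilicity; on this read-out lower numbers stand for lower lipophilicity and higher numbers for higher lipophilicity. Compound 1 `CC(/C=C/CC(C)CCCC(C)C)=C\C(=O)OCC(C)C` gives 7.69. Going by the values given here, compound 2 `CCCCOC(=O)/C=C(C)/C=C/CC(C)CCCC(C)(C)OC` gives 6.62, the lower of the two numbers; its only neighbour is compound 1, whose value lies higher by a gap beyond the scatter.

Compound 3 `COC(C)(C)CCCC(C)C/C=C/C(C)=C/C(=O)SC(C)C` has not yet been measured in this assay. It differs from compound 2 in a single place: isopropylsulfanyl in place of butoxy on a carbonyl carbon. Among the compounds with values here, no measured pair in this set shows the same change, so the expectation for compound 3 rests on compound 2 alone, together with the nature of the exchange at the carbonyl carbon.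

The step expected from compound 2 to compound 3 in this assay is a number 0.28 log units higher from compound 2 to compound 3 (within the scatter), a small rise that barely clears the scatter. Compound 3 is therefore estimated at 6.9, with a range from 6.4 to 7.4.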

Compound 3, partition coefficient: 7.19
Compound 3: the middle estimate sits 0.29 log units below what was measured; measured number inside the range.
By their numbers in this assay, from the lowest: compound 2; then compound 3; then compound 1.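

In this assay, going by these compounds alone, isopropylsulfanyl in place of butoxy on a carbonyl carbon gives a number 0.57 log units higher from compound 2 to compound 3 (beyond the scatter) and thus shows, for the first time, that the read-out responds to a change at this position. The step appears even though the entering group has one heavy atom fewer than the group it replaces and the two carry the same count of hydrogen-bond donors and acceptors. Nothing in the available evidence explains the size or direction of this step.

Because the exchange alters both the linking atom and the shape of the chain, the compounds shown cannot assign the step to either alone. As far as these compounds go, whether an isopropoxy or a butylsulfanyl group on the same carbonyl carbon would carry all, part or none of it remains open.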